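Nitro in place of bromo on the aryl ring of compound 2

The source may report more compounds than this note shows. Statements on the series, on what has been measured and on what is new or still open speak of the compounds shown alone.

Within the data shown here, compound 1 `O=c1c2ccccc2c(Cc2ccc(Cl)cc2)nn1-c1ccc([N+](=O)[O-])cc1` and compound 2 `COc1ccc(Cc2nn(-c3ccc(Br)cc3)c(=O)c3ccccc23)cc1OC` share one core but differ in two places, so no single step joins them. In a functional assay on aorta with Alpha-1D adrenergic receptor (Rattus norvegicus) as the target (a higher number here means that more compound is needed for the effect, a lower number that less compound is needed), compound 1 gives 29000 nM. For compound 2 this assay reports only a limit, > 100000 nM, and not a number. That limit, (the limit of > 100000 nM in this assay, at which 1 of the 2 values shown sits), is all that is known of compound 2 in this assay.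

Compound 3 `COc1ccc(Cc2nn(-c3ccc([N+](=O)[O-])cc3)c(=O)c3ccccc23)cc1OC` has not yet been measured. It differs from compound 2 by nitro in place of bromo on an aromatic carbon. No measured pair differs in one place only, so the size of such a step is not shown by any pair. Compound 1 also carries a 4-nitrophenyl and gives a number in this assay, which is the only hint of direction. The expected step of an at least 1.6-fold lower number from compound 2 to compound 3 (0.22 log units; that floor lies within the scatter) is therefore toward a lower number, but small and possibly within the scatter. Compound 3 is estimated at 60000 nM, with a range from 20000 nM to 150000 nM.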

Compound 3, half-maximal effective concentration: > 100000 nM
Compound 3 was reported as a limit; the forecaster's own chance of this, stated with the estimate: 50%; middle value at least 1.6-fold (0.22 log units) away from the limit.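

For compound 3, this assay gives only a limit, > 100000 nM, and not a number; with limits at both ends, the change from 4-bromophenyl to 4-nitrophenyl cannot be read. Among these compounds, the 4-nitrophenyl alone therefore does not secure a number here, and the one readable change lies on the other side of the shared core: 3,4-dimethoxyphenyl in place of 4-chlorophenyl on a saturated chain carbon bound to an aromatic carbon gives an at least 3.4-fold higher number from compound 1 to compound 3 (0.53 log units; beyond the scatter), a step beyond the scatter whose full size remains unknown. Both compounds bearing the 3,4-dimethoxyphenyl now sit at the same limit: the limit of > 100000 nM in this assay, at which 2 of the 3 values shown sit.

Going by these compounds, the effect of nitro in place of bromo remains open, and it could be read only on a pair that gives numbers at both ends, such as one carrying the 4-chlorophenyl on the chain carbon. Also open, on these data alone, is whether an amine or a carboxylic acid at this aromatic carbon, or a methoxy on the chain-bound ring in place of the 3,4-dimethoxyphenyl, would give a number in this assay.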